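Trimming the crotonamide-type chain in a quinazoline series

The compounds below may be only part of what the source reports. "The series", "measured", "known", "first", "only" and "open" are said of these compounds alone.

Of the compounds shown here, three have been measured in a functional assay on PC-3 cells (Homo sapiens) for antiproliferative activity, read by MTT assay, with a stated time of 72 h; a lower number here means a stronger inhibitor, a higher number a weaker inhibitor. Compound 1 `C/C=C/C(=O)Nc1cc2c(N3CCc4ccccc43)ncnc2cc1O[C@@H]1CCOC1` gives 5220 nM. Compound 2 `C/C=C/C(=O)Nc1cc2c(N3CCCc4ccccc43)ncnc2cc1OC` gives 7520 nM. Compound 3 `CC(C)=CC(=O)Nc1cc2c(N3CCCc4ccccc43)ncnc2cc1O[C@@H]1CCOC1` gives 9020 nM. On these numbers compound 3 carries the highest value of the three, but its gaps to compound 2 and to compound 1 both lie within the scatter of this assay, so the three compounds cannot be separated from one another.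

The next compound, compound 4 `C/C=C/C(=O)Nc1cc2c(N3CCCc4ccccc43)ncnc2cc1O[C@@H]1CCOC1`, differs from compound 3 in a single place: prop-1-en-1-yl in place of 2-methylprop-1-en-1-yl on a carbonyl carbon. Among the measured compounds shown here, no pair of measured compounds shows exactly this change, so no measured step can be carried over. Compounds 1 and 2 both carry the prop-1-en-1-yl chain, and their values in this assay sit a little under that of compound 3, though within the scatter.

On that basis compound 4 is expected to land close to compound 3, with a step from a 1.4-fold lower number from compound 3 to compound 4 (0.14 log units; within the scatter) that is small and directed toward a lower number, not clearly beyond the scatter. The estimate for compound 4 in this assay is 6500 nM, with a likely range from 3000 nM to 14000 nM.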

Compound 4, half-maximal inhibitory concentration: 9350 nM
Compound 4: the middle estimate sits 1.4-fold (0.16 log units) below what was measured, and the stated range covers the measured number.
By their numbers in this assay, from the lowest: compounds 1, 2, 3 and 4 (each within the scatter of the next).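

In this assay, among the compounds shown here, the exchange of 2-methylprop-1-en-1-yl for prop-1-en-1-yl on a carbonyl carbon gives a 1.0-fold higher number from compound 3 to compound 4 (0.02 log units; within the scatter) and offers the first direct reading of this change, which does not separate the two chains at this position. The new structure also gives single-place readings for two other parts of the molecule: oxolan-3-yl in place of methyl on an oxygen on an aromatic ring gives a 1.2-fold higher number from compound 2 to compound 4 (0.09 log units; within the scatter) and 1,2,3,4-tetrahydroquinolin-1-yl in place of 2,3-dihydro-1H-indol-1-yl on an aromatic carbon gives a 1.8-fold higher number from compound 1 to compound 4 (0.25 log units; within the scatter) so that none of the three exchanges can be told from the scatter. No supporting measurement bears on this result.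

The compounds shown leave open whether any group at these places would move the number beyond the scatter, for instance a dimethylamino group at the end of a longer chain on the carbonyl carbon, or a morpholine-bearing chain on the oxygen. They also leave open whether the absence of a clear step holds for other pairings of these groups on the shared core.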